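The source may hold more compounds than are shown below. What is called first, only, known or untested is meant among the compounds shown, and "the series" means these compounds.

In a functional assay on U-251 cells (Homo sapiens) for antiproliferative activity, with a stated time of 48 h (a higher number here means that more compound is tolerated, a lower number that less compound is tolerated), compound 1 `Cc1cc(O)c(C2=NN(c3ccc(S(N)(=O)=O)cc3)C(c3ccccc3O)C2)cc1Cl` gives 26900 nM.
Compound 2 `Cc1cc(O)c(C2=NN(c3ccc(S(N)(=O)=O)cc3)C(/C=C/c3ccccc3)C2)cc1Cl` gives 39500 nM.
Compound 3 `COc1ccc(C2CC(c3cc(Cl)c(C)cc3O)=NN2c2ccc(S(N)(=O)=O)cc2)cc1OC` gives 48200 nM.

Compound 3 stands together with the other two, since nothing separates the three numbers beyond the scatter: a 1.8-fold higher number from compound 1 to compound 3 (0.25 log units; within the scatter), a 1.2-fold higher number from compound 2 to compound 3 (0.09 log units; within the scatter) and a 1.5-fold higher number from compound 1 to compound 2 (0.17 log units; within the scatter). Compound 4 `COc1ccc(C2CC(c3cc(Cl)c(C)cc3O)=NN2c2ccc(S(N)(=O)=O)cc2)c(OC)c1OC` differs from compound 3 by methoxy in place of hydrogen on an aromatic carbon. Each measured step exchanged the whole group on that saturated ring carbon, and none of them went beyond the scatter, so a small addition to the same group gives no reason to expect a visible move. Among the measured compounds shown here, no step adding a methoxy to an existing ring has been measured. In this assay, compound 4 is expected to show a 1.0-fold lower number from compound 3 to compound 4 (0.00 log units; within the scatter). Compound 4 is therefore estimated at 48000 nM, within the range 22000 nM to 105000 nM.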

Compound 4, concentration lethal to 50% of the cells: 29700 nM
Compound 4: the middle estimate sits 1.6-fold (0.21 log units) above what was measured; low and high end bracket the measured number.
By their numbers in this assay, from the lowest: compounds 1, 4, 2 and 3 (each within the scatter of the next).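

In this assay, placing a methoxy on an aromatic carbon of the ring already carried by the saturated ring carbon gives a step within the scatter (a 1.6-fold lower number from compound 3 to compound 4 (0.21 log units; within the scatter)). The 2,3,4-trimethoxyphenyl group also stays within the scatter of the two other groups tried at that carbon (a 1.3-fold lower number from compound 2 to compound 4 (0.12 log units; within the scatter); a 1.1-fold higher number from compound 1 to compound 4 (0.04 log units; within the scatter)). No supporting measurement is available to explain these small steps. The compounds shown leave open whether an amine or a carboxylic acid on that ring would move the number beyond the scatter.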